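Working notes: methoxy to ethoxy from compound 3

This account rests on a few compounds, and the source may have more. Where it says the series, first, only, none or still open, it means among the compounds named here.

In a functional assay on MCF7 cells (Homo sapiens) for antiproliferative activity (on this read-out higher numbers stand for weaker inhibition of growth and lower numbers for stronger inhibition of growth), compound 1 `COc1ccc(-c2nc3cc(F)ccc3s2)cc1F` gives 870 nM and compound 2 `COc1ccc(-c2nc3cc(F)ccc3s2)cc1Cl` gives 760 nM. Chloro in place of fluoro thus gives a 1.1-fold lower number from compound 1 to compound 2 (0.06 log units; within the scatter). Compound 3 `COc1ccc(-c2nc3cc(F)ccc3s2)cc1OC` gives < 0.1 nM, which is a limit of this assay and not a number. Methoxy in place of fluoro gives an at least 8700-fold lower number from compound 1 to compound 3 (3.93 log units; beyond the scatter), and methoxy in place of chloro gives an at least 7600-fold lower number from compound 2 to compound 3 (3.88 log units; beyond the scatter), so compound 3 is the strongest of the three.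

Compound 4 `CCOc1cc(-c2nc3cc(F)ccc3s2)ccc1OC` differs from compound 3 by one change, methoxy to ethoxy: methyl in place of hydrogen on a saturated chain carbon bound to an oxygen on an aromatic ring. Among the compounds with values here, no measured step covers this change. The two large steps to compound 3 are the nearest evidence, as they show how much this assay responds to the group at that place. Both of those steps bring in the methoxy, whereas compound 4 keeps the oxygen and only adds a methyl. A step to a higher number is expected for compound 4, far smaller than those two, and the result could also come back as a limit. The expected step is an at least 10-fold higher number from compound 3 to compound 4 (1.00 log units; beyond the scatter). For compound 4 the estimated value is 1 nM, with an expected range of 0.1 nM to 30 nM.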

Compound 4, concentration for 50% growth inhibition: 80 nM
Compound 4: middle estimate off by 80-fold (1.90 log units), on the low side; measured number above the stated range.
By their numbers in this assay, from the lowest: compound 4; then compounds 2 and 1 (each within the scatter of the next). At a limit, below all of these: compound 3.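

At the group on the aromatic ring where compound 3 carries a methoxy, the assay turns out to be sensitive to far more than the presence of the oxygen. In this assay, a single methyl in place of hydrogen on a saturated chain carbon bound to an oxygen on an aromatic ring gives an at least 800-fold higher number from compound 3 to compound 4 (2.90 log units; beyond the scatter), so keeping the oxygen does not keep the full strength of the methoxy compound. Ethoxy still retains part of the gain over the halogens, with a 9.5-fold lower number from compound 2 to compound 4 (0.98 log units; beyond the scatter) and an 11-fold lower number from compound 1 to compound 4 (1.04 log units; beyond the scatter), which places compound 4 clearly apart from both compound 1 and compound 2, yet the first of these three steps gives only a bound, since the value of compound 3 is a limit of the assay and not a number: the limit of < 0.1 nM in this assay, at which 1 of the 4 values shown sits.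

The compounds shown leave open whether the number keeps rising along a longer chain such as propoxy, or how a branched isopropoxy would compare with ethoxy. They also leave open how a hydroxy or an amine would read out in place of the methoxy of compound 3.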